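The compounds below may be only part of what the source reports. "The series", "measured", "known", "first", "only" and "open" are said of these compounds alone.

Measured compounds:
- compound 1, `COc1ccc2nc(C)cc(OCC(=O)Nc3cc(C)cc(C)c3)c2c1`: 5.64
- compound 2, `CCOc1ccc2nc(C)cc(OCC(=O)Nc3cc(C)cc(C)c3)c2c1`: 5.98
- compound 3, `Cc1cc(C)cc(NC(=O)COc2cc(C)nc3ccc(OCc4ccccc4)cc23)c1`: 7.03

In a physicochemical assay for lipophilicity, read by HPLC, in phosphate buffer, measured as chromatographic lipophilicity, at pH 7.4 (on this read-out lower numbers stand for lower lipophilicity and higher numbers for higher lipophilicity), compound 1 gives the lowest of the three numbers. Its nearest neighbour is compound 2, reached by a number 0.34 log units higher from compound 1 to compound 2 (beyond the scatter); the furthest is compound 3, reached by a number 1.39 log units higher from compound 1 to compound 3 (beyond the scatter), and the two larger compounds are separated by a number 1.05 log units higher from compound 2 to compound 3 (beyond the scatter).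

Compound 4, `COc1ccc2nc(C)cc(OCC(=O)Nc3ccc(F)cc3)c2c1`, has not yet been measured in this assay. It differs from compound 1 at the amide end rather than at the ether end: 4-fluorophenyl in place of 3,5-dimethylphenyl on an amide-type nitrogen. For the measured compounds named here, none of the measured steps touches this position, so no step bears on it directly. What the measured steps do show is that adding carbon at the ether end raised the number, as in a number 0.34 log units higher from compound 1 to compound 2 (beyond the scatter), and the change to compound 4 goes the other way in count, with one fewer heavy atom and the two methyl groups of the 3,5-dimethylphenyl gone. A drop beyond the scatter is therefore expected, of a size that the data cannot fix closely. Compound 4 is expected to give 4.9 in this assay, within 4.5 to 5.3, which would mean an expected a number 0.74 log units lower from compound 1 to compound 4 (beyond the scatter).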

Compound 4, distribution coefficient: 4.49
For compound 4 the middle estimate is 0.41 log units above the measured one, outside the stated range (below it).
By their numbers in this assay, from the lowest: compound 4; then compound 1; then compound 2; then compound 3.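

At the amide end, the position on an amide-type nitrogen whose other neighbour is the carbonyl carbon, this assay proves sensitive to the aryl group: on replacing 3,5-dimethylphenyl with 4-fluorophenyl, the reading shows a number 1.15 log units lower from compound 1 to compound 4 (beyond the scatter). For the compounds shown here, the earlier steps were all changes at the ether end and all ran upward, so this is the first step to run downward, and it places compound 4 lowest of the four. In size it is well beyond the smallest ether-end step, a number 0.34 log units higher from compound 1 to compound 2 (beyond the scatter), and it counts as large, as does a number 1.39 log units higher from compound 1 to compound 3 (beyond the scatter); no measurement given here accounts for the drop.

This single step removes two methyl groups and adds a fluorine at once, so the compounds shown leave open how much of it goes with each part, which an unsubstituted phenyl on the same nitrogen would help to divide. Also open, as far as these compounds go, are whether the same exchange gives a similar step on the ether-end variants of compound 2 and compound 3, and how an aryl group carrying an amine or a carboxylic acid would read at this position.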